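The compounds below may be only part of what the source reports. "The series", "measured", "known", "first", "only" and "open" are said of these compounds alone.

Compound 1 `COc1cc(N(C)CCN(C)C)c(NC(=O)/C=C\C(C)C)cc1Nc1ncc(C#N)c(-c2cn(C)c3ccccc23)n1` gives 1110 nM in a functional assay on NCI-H1975 cells (Homo sapiens) for antiproliferative activity, read by MTT assay, with a stated time of 72 h; a higher number here means a weaker inhibitor, a lower number a stronger inhibitor. Compound 2 `CCC/C=C\C(=O)Nc1cc(Nc2ncc(C#N)c(-c3cn(C)c4ccccc34)n2)c(OC)cc1N(C)CCN(C)C` gives 823 nM in this assay. Compound 3 `COc1cc(N(C)CCN(C)C)c(NC(=O)/C=C\C(C)C)cc1Nc1ncc(C#N)c(-c2cn(C)c3ccc(F)cc23)n1` gives 1130 nM in this assay.

The change from compound 1 to compound 2 is propyl in place of isopropyl on a double-bonded chain carbon bound to a double-bonded chain carbon, and it produced a 1.3-fold lower number from compound 1 to compound 2 (0.13 log units; within the scatter). Compound 3 differs from compound 1 by fluoro in place of hydrogen on an aromatic carbon, which produced a 1.0-fold higher number from compound 1 to compound 3 (0.01 log units; within the scatter). Compound 4 `CCC/C=C\C(=O)Nc1cc(Nc2ncc(C#N)c(-c3cn(C)c4ccc(F)cc34)n2)c(OC)cc1N(C)CCN(C)C` has not yet been measured in this assay; it differs from compound 3 by propyl in place of isopropyl on a double-bonded chain carbon bound to a double-bonded chain carbon, the same change as that from compound 1 to compound 2, made on the same place. For the measured compounds named here, compound 4 is therefore expected to show a step of a 1.3-fold lower number from compound 3 to compound 4 (0.11 log units; within the scatter), resting on the single earlier instance of this change, a 1.3-fold lower number from compound 1 to compound 2 (0.13 log units; within the scatter), and on the value of compound 3, 1130 nM. The estimate for compound 4 is 880 nM, between 400 nM and 1900 nM.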

Compound 4, half-maximal inhibitory concentration: 2420 nM
The estimate for compound 4 lay 2.8-fold (0.44 log units) below the measured number; measured number above the stated range.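

On the core carrying fluoro, propyl in place of isopropyl gave a 2.1-fold higher number from compound 3 to compound 4 (0.33 log units; beyond the scatter) in this assay, so the step seen on the core of compound 1 did not carry over unchanged: the same change on two cores in this assay, a 1.3-fold lower number (0.13 log units; within the scatter) from compound 1 to compound 2 and a 2.1-fold higher number (0.33 log units; beyond the scatter) from compound 3 to compound 4, 2.9-fold (0.46 log units) apart, beyond the scatter of two such steps

Read the other way, fluoro in place of hydrogen gave a 2.9-fold higher number from compound 2 to compound 4 (0.47 log units; beyond the scatter), and this step likewise differs from its counterpart on the isopropyl chain: the same change on two cores in this assay, a 1.0-fold higher number (0.01 log units; within the scatter) from compound 1 to compound 3 and a 2.9-fold higher number (0.47 log units; beyond the scatter) from compound 2 to compound 4, 2.9-fold (0.46 log units) apart, beyond the scatter of two such steps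

Both comparisons rest on the same four compounds, so they record a single result: here the two changes do not add up independently, though this does not show why, nor that it holds elsewhere in the series.

The compounds shown leave open whether chloro in place of fluoro, or a longer chain such as butyl in place of propyl, would show the same dependence on its partner group.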